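Swapping the aryl sulfone in a shared quinoline-like series

The compounds below may be only part of what the source reports. "The series", "measured", "known", "first", "only" and "open" are said of these compounds alone.

Of the compounds shown here, three built on one shared core have been measured in an assay on isolated protein for displacement of a labelled ligand from metabotropic glutamate receptor 5 (Homo sapiens), with a stated time of 60 min, tested at 1 uM; on this read-out higher numbers stand for more inhibition at the one concentration tested (going by the name of the read-out) and lower numbers for less inhibition. Compound 1 `COc1ccc(S(=O)(=O)c2cnc3cc(F)ccc3c2N2CCC(C)CC2)cc1OC` gives 83%, compound 2 `CC1CCN(c2c(S(=O)(=O)c3ccc(F)c(F)c3)cnc3cc(Cl)ccc23)CC1` gives 90%, and compound 3 `CC1CCN(c2c(S(=O)(=O)c3ccc(C#N)cc3)cnc3cc(F)ccc23)CC1` gives 83%. On these numbers compound 3 stands level with compound 1 and, with it, at the lower end of the three, while compound 2 lies somewhat higher, though its gap to compound 3 is within the scatter, so no order among the three can be claimed.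

Among the measured compounds shown here, the one step measured within this set, no change at the digits printed from compound 1 to compound 3 (within the scatter), shows that exchanging one aryl group on the sulfonyl sulfur for another left the read-out unchanged. Compound 4 `CC1CCN(c2c(S(=O)(=O)c3ccc(F)c(F)c3)cnc3cc(F)ccc23)CC1` is obtained from compound 3 by 3,4-difluorophenyl in place of 4-cyanophenyl on a sulfonyl sulfur. That same aryl group is already present on the sulfonyl sulfur of compound 2, which differs from compound 4 elsewhere in the core, and in this assay compound 2 gives 90%. For the measured compounds named here, because the only comparable exchange, no change at the digits printed from compound 1 to compound 3 (within the scatter), produced no change beyond the scatter, and because compound 2 with the entering group reads 90%, compound 4 is expected to sit close to its neighbours. The estimated step is a number 4 percentage points higher from compound 3 to compound 4 (within the scatter). For compound 4 the expected value in this assay is 87%, with a range from 75% to 95%.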

Compound 4, a percentage reported as inhibition, at one concentration (the size of the read-out at that concentration, not a potency): 94%
Beside the measured number, compound 4's estimate is 7 percentage points below it, within the range that was stated.
By their numbers in this assay, from the lowest: compounds 1, 3, 2 and 4 (each within the scatter of the next, the first and the last beyond it).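

The aryl group on the sulfonyl sulfur now proves able to move the reading in this assay: the exchange of 4-cyanophenyl for 3,4-difluorophenyl gives a number 11 percentage points higher from compound 3 to compound 4 (beyond the scatter), and that of 3,4-dimethoxyphenyl for 3,4-difluorophenyl gives a number 11 percentage points higher from compound 1 to compound 4 (beyond the scatter), whereas the earlier exchange between the two non-fluorinated aryl groups gave no change at the digits printed from compound 1 to compound 3 (within the scatter). Both steps beyond the scatter are modest and share the same entering group, so this position separates 3,4-difluorophenyl from the other two aryl groups, while those two remain level with each other. On the core, fluoro in place of chloro on an aromatic carbon gives a number 4 percentage points higher from compound 2 to compound 4 (within the scatter), so that exchange cannot be read as a real difference, and nothing available explains why the 3,4-difluorophenyl group reads differently from the other aryl groups.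

These readings come from one concentration and are not potencies, so they leave open how far compound 2 and compound 4 would differ on a full concentration curve. They also leave open whether the step holds for a single fluoro on the phenyl ring, or whether a non-aromatic group such as cyclohexyl or methyl on the sulfonyl sulfur would keep the reading.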